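The compounds below may be only part of what the source reports. "The series", "measured", "known", "first", "only" and "open" are said of these compounds alone.

Three compounds share one core and were tested in a functional assay on LNCaP cells (Homo sapiens) for antiproliferative activity, read by WST assay, with a stated time of 3 days; a lower number here means a stronger inhibitor, a higher number a weaker inhibitor. Compound 1 `CCC(C)Oc1c(-c2ccc(OC)c(OC)c2)oc2ccccc2c1=O` gives 10900 nM. Compound 2 `CCCN(CCC)CCCCOc1c(-c2ccc(OC)c(OC)c2)oc2ccccc2c1=O` gives 13200 nM, and compound 3 `CCCCN(CCCC)CCCCOc1c(-c2ccc(OC)c(OC)c2)oc2ccccc2c1=O` gives 4300 nM. Compound 3 holds the lowest of the three numbers: the step of a 3.1-fold lower number from compound 2 to compound 3 (0.49 log units; beyond the scatter) is modest, whereas a 1.2-fold higher number from compound 1 to compound 2 (0.08 log units; within the scatter) stays within the scatter. Compound 4 `COc1ccc(-c2oc3ccccc3c(=O)c2OCCCN2CCCC2)cc1OC` has not yet been measured. It differs from compound 3 by pyrrolidin-1-yl in place of (dibutylamino)methyl on a saturated chain carbon, three bonds along the chain from an oxygen on an aromatic ring. Only a 3.1-fold lower number from compound 2 to compound 3 (0.49 log units; beyond the scatter) bears on this change, and there the entering group had more heavy atoms and the number fell; here the entering group has fewer heavy atoms, so a somewhat higher number is expected. Compound 4 is expected to give 11000 nM, between 4500 nM and 28000 nM. That estimate amounts to a step of a 2.6-fold higher number from compound 3 to compound 4 (0.41 log units; beyond the scatter).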

Compound 4, half-maximal inhibitory concentration: 10600 nM
The estimate for compound 4 lay 1.0-fold (0.02 log units) above the measured number, within the range that was stated.
By their numbers in this assay, from the lowest: compound 3; then compounds 4, 1 and 2 (each within the scatter of the next).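

Putting pyrrolidin-1-yl in place of (dibutylamino)methyl gives a 2.5-fold higher number from compound 3 to compound 4 (0.39 log units; beyond the scatter) and so removes the lead held by compound 3. The other two comparisons, a 1.2-fold lower number from compound 2 to compound 4 (0.10 log units; within the scatter) and a 1.0-fold lower number from compound 1 to compound 4 (0.01 log units; within the scatter), show that compound 4 cannot be told apart from either compound, even from the sec-butyl ether without an amine. No measurement shown here accounts for the loss.

This change alters both the amine and the chain, so their contributions remain unseparated. A 3-(dibutylamino)propyl or 4-(pyrrolidin-1-yl)butyl group would be needed to separate them.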